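The source may report more compounds than this note shows. Statements on the series, on what has been measured and on what is new or still open speak of the compounds shown alone.

In a functional assay (trachea) with Cavia porcellus as the target (a higher number here means a weaker inhibitor, a lower number a stronger inhibitor), compound 1 (`CCCn1nc(-c2cccnc2)c2ccccc2c1=O`) gives 3160 nM, compound 2 (`COCCn1nc(-c2cccnc2)c2ccccc2c1=O`) gives 9330 nM and compound 3 (`O=c1c2ccccc2c(-c2cccnc2)nn1CCSc1nccs1`) gives 10500 nM. Compound 3 thus stands level with compound 2, and both are weaker inhibitors than compound 1. Compound 4 (`O=c1c2ccccc2c(-c2cccnc2)nn1CCCCSc1ncccn1`) differs from compound 3 in one place, on a saturated chain carbon, two bonds along the chain from an aromatic nitrogen: 2-((pyrimidin-2-yl)sulfanyl)ethyl in place of (1,3-thiazol-2-yl)sulfanyl on a saturated chain carbon, two bonds along the chain from an aromatic nitrogen. The nearest guides are changes at that same place. They gave a 3.0-fold higher number from compound 1 to compound 2 (0.47 log units; beyond the scatter) and a 3.3-fold higher number from compound 1 to compound 3 (0.52 log units; beyond the scatter), both modest, while exchanging one large end group for another gave a 1.1-fold higher number from compound 2 to compound 3 (0.05 log units; within the scatter). The expected step is therefore small, with no clear direction: a 1.2-fold lower number from compound 3 to compound 4 (0.07 log units; within the scatter). For compound 4 the estimated value in this assay is 9000 nM, with an expected range of 3000 nM to 27000 nM.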

Compound 4, half-maximal inhibitory concentration: 6170 nM
Compound 4: the middle estimate sits 1.5-fold (0.16 log units) above what was measured; measured number inside the range.
By their numbers in this assay, from the lowest: compounds 1, 4, 2 and 3 (each within the scatter of the next, the first and the last beyond it).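

In this assay, the longer chain with its pyrimidine end group stays within the scatter of all three earlier compounds (a 1.7-fold lower number from compound 3 to compound 4 (0.23 log units; within the scatter); a 1.5-fold lower number from compound 2 to compound 4 (0.18 log units; within the scatter); a 2.0-fold higher number from compound 1 to compound 4 (0.29 log units; within the scatter)). Compound 2 and compound 3 both lie beyond the scatter of compound 1, but compound 4 does not, so this position can carry 2-((pyrimidin-2-yl)sulfanyl)ethyl without separating clearly from compound 1. Nothing measured here offers a reason for this.

Chain length and end ring differ together in compound 4, so their separate contributions remain open. The compounds shown also cannot tell how an amine or a carboxylic acid at the chain end would behave.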